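Amine acylation in the triarylethylene series: compound 4

The source may hold more compounds than are shown below. What is called first, only, known or untested is meant among the compounds shown, and "the series" means these compounds.

The parent amine compound 1 `COc1ccc(/C(=C(/CCN)c2ccccc2)c2ccccc2)cc1` gives in a functional assay on MCF7 cells (Homo sapiens) for cytotoxicity, read by MTT assay, with a stated time of 72 h (a higher number here means a weaker inhibitor, a lower number a stronger inhibitor), a value of 16900 nM. Compound 2 `COc1ccc(/C(=C(/CCNC(=O)N2CCOCC2)c2ccccc2)c2ccccc2)cc1` reaches only the limit of this assay, at > 50000 nM. Compound 3 `COc1ccc(/C(=C(/CCNC(=O)N2CCCC2)c2ccccc2)c2ccccc2)cc1` likewise sits at the limit, > 50000 nM, so compound 3 stands on a limit only, and one further value in this set is also a limit. The two readable steps, an at least 2.9-fold higher number from compound 1 to compound 2 (0.47 log units; beyond the scatter) and an at least 2.9-fold higher number from compound 1 to compound 3 (0.47 log units; beyond the scatter), both rest on (the limit of > 50000 nM in this assay, at which 2 of the 3 values shown sit); the step that the two limits leave unreadable from compound 2 to compound 3 cannot be sized, as both ends are limits.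

Compound 4 `COc1ccc(/C(=C(/CCNC(=O)C(=O)N2CCCCC2)c2ccccc2)c2ccccc2)cc1` differs from compound 3 by (piperidin-1-yl)carbonyl in place of pyrrolidin-1-yl on a carbonyl carbon. The change keeps the acyl group on the amine nitrogen that in compound 2 and compound 3 already carried the value to the limit, and the comparison between those two gave nothing readable. No step beyond the scatter in this assay is therefore expected, and the value of compound 4 is expected to stay at or beyond the limit. The expected step is a step that the limit leaves unreadable from compound 3 to compound 4. Compound 4 is estimated at 80000 nM, with a range from 30000 nM to 300000 nM.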

Compound 4, half-maximal inhibitory concentration: > 50000 nM
Compound 4 gave a limit, no number; the forecaster's own chance of this, stated with the estimate: 75%; the middle value does not contradict the limit.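

Compound 4 extends the acyl group on the amine nitrogen by one carbonyl and carries piperidin-1-yl, and in this assay its result is again a limit, > 50000 nM. Against the parent amine the change gives an at least 2.9-fold higher number from compound 1 to compound 4 (0.47 log units; beyond the scatter), so the extended ((piperidin-1-yl)carbonyl)carbonyl group joins the two shorter acyl groups of compound 2 and compound 3, and none of the acylated compounds shown goes against this. The steps among compound 2, compound 3 and compound 4 cannot be read, so neither the added carbonyl nor the ring exchange can be sized: the limit of > 50000 nM in this assay, at which 3 of the 4 values shown sit.

From the compounds shown here alone, how far the true values of the acylated compounds lie past the limit stays open. Going by these compounds, whether any acylation of this nitrogen keeps the value of compound 1, 16900 nM, also stays open; a plain acetyl group, an N-methyl amine or a longer chain carrying the free amine would address this.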